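Swapping the Amide Amine on the Thiophen-3-yl Core

The compounds below may be only part of what the source reports. "The series", "measured", "known", "first", "only" and "open" are said of these compounds alone.

Measured so far:
compound 1 `CC1=C(C(=O)NC(C)C)C(c2cccs2)NC(=O)N1` gives 40%
compound 2 `CCN(CC)C(=O)C1=C(C)NC(=O)NC1c1cccs1` gives 22%
compound 3 `CC1=C(C(=O)NC(C)C)C(c2ccsc2)NC(=O)N1` gives 3%

All three were tested in an assay on membranes from HEK293 cells for displacement of a labelled ligand from adenosine receptor A2b (Homo sapiens), read by scintillation counting, with a stated time of 30 min, tested at 1 uM; a lower number here means less inhibition, a higher number more inhibition at the concentration tested (going by the name of the read-out). Two single changes start from compound 1. One is diethylamino in place of isopropylamino on a carbonyl carbon, and it produced a number 18 percentage points lower from compound 1 to compound 2 (beyond the scatter). The other is how the two cores differ, (thiophen-3-yl in place of thiophen-2-yl on a saturated ring carbon), and it produced a number 37 percentage points lower from compound 1 to compound 3 (beyond the scatter), leaving compound 3 lowest of the three.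

Compound 4 `CCN(CC)C(=O)C1=C(C)NC(=O)NC1c1ccsc1` has not yet been measured in this assay. It differs from compound 3 by diethylamino in place of isopropylamino on a carbonyl carbon, the same change as from compound 1 to compound 2, made at the same place, only on the core of compound 3. That earlier step was a modest drop. The step here is expected to be a number 3 percentage points lower from compound 3 to compound 4 (within the scatter), smaller, because compound 3 already gives 3% and little room remains below it. Compound 4 is estimated at 0%, from -8% to 10%.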

Compound 4, a percentage reported as inhibition, at one concentration (the size of the read-out at that concentration, not a potency): 11%
For compound 4 the middle estimate is 11 percentage points below the measured one, and the stated range ends below it.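

In this assay, the effect of diethylamino in place of isopropylamino does not carry over from one core to the other. Among these compounds, the clear drop on the core of compound 1 has no counterpart on the core of compound 3, where the step is a number 8 percentage points higher from compound 3 to compound 4 (within the scatter): the same change on two cores in this assay, a number 18 percentage points lower (beyond the scatter) from compound 1 to compound 2 and a number 8 percentage points higher (within the scatter) from compound 3 to compound 4, 26 percentage points apart, beyond the scatter of two such steps. Thiophen-3-yl in place of thiophen-2-yl gives a lower number with both amines, here a number 11 percentage points lower from compound 2 to compound 4 (beyond the scatter), but the size of that step depends on the amine: the same change on two cores in this assay, a number 37 percentage points lower (beyond the scatter) from compound 1 to compound 3 and a number 11 percentage points lower (beyond the scatter) from compound 2 to compound 4, 26 percentage points apart, beyond the scatter of two such steps. So the two changes do not simply add up across these four compounds, though the data do not show why or whether this holds for other amines.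

Going by these compounds, it remains open how a cyclic amine such as piperidine, or a longer chain, would behave in place of isopropylamino on either core.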